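This account rests on a few compounds, and the source may have more. Where it says the series, first, only, none or still open, it means among the compounds named here.

Of the compounds shown here, two sharing one core have been tested so far in a functional assay on HCT-116 cells (Homo sapiens) for cytotoxicity, read by MTT assay; on this read-out higher numbers stand for weaker inhibition and lower numbers for stronger inhibition. Compound 1 `Cc1cc(O)c(C(=O)/C=C/c2ccc(F)cc2)c(=O)o1`, with fluoro on an aromatic carbon, gives > 100000 nM, which is a limit of the assay and not a number. Compound 2 `CCOc1ccc(/C=C/C(=O)c2c(O)cc(C)oc2=O)cc1`, with ethoxy there, gives > 100000 nM, which is also a limit and not a number. Compound 2 therefore has no exact value, and its standing is the limit of > 100000 nM in this assay, at which 2 of the 2 values shown sit.

The next compound is compound 3 `Cc1cc(O)c(C(=O)/C=C/c2ccc([N+](=O)[O-])cc2)c(=O)o1`, which has nitro in place of ethoxy on an aromatic carbon, para to a large group: nitro in place of ethoxy on an aromatic carbon. For the measured compounds named here, only one measured step bears on this change, since it also replaces one group with another on an aromatic carbon. That is a step that the two limits leave unreadable from compound 1 to compound 2, and it gives no size to build on. Going by the values given here, no step of any particular size or direction can therefore be expected in this assay from the numbers alone. The expected step is a number no higher from compound 2 to compound 3 (the limit leaves the size open), and a further limit is the likeliest report. Compound 3 is estimated at 100000 nM, with an expected range from 40000 nM to 250000 nM.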

Compound 3, half-maximal inhibitory concentration: 65000 nM
Compound 3: the middle estimate sits 1.5-fold (0.19 log units) above what was measured; the measured number falls inside the stated range.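

In this assay, for the compounds shown here, compound 3 gives 65000 nM, the first exact number, so a group on this aromatic carbon, para to a large group, can bring the reading within the range the assay can count. Nitro in place of ethoxy gives an at least 1.5-fold lower number from compound 2 to compound 3 (0.18 log units; that floor lies within the scatter), and nitro in place of fluoro gives an at least 1.5-fold lower number from compound 1 to compound 3 (0.18 log units; that floor lies within the scatter); each change thus has a floor for its size but no full size, and neither floor alone separates the change from the ordinary spread of repeated measurements. Compound 1 and compound 2 each remain a limit of the assay and not a number: the limit of > 100000 nM in this assay, at which 2 of the 3 values shown sit.

On these data alone, the true size of both steps stays open, and so does whether any group at this position can take the number much lower than compound 3 does. The compounds shown also give no reading for an amine, a carboxylic acid or a longer chain such as butoxy on this same aromatic carbon, so no trend across groups can yet be drawn.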